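From 4-hydroxyphenyl to 2,3-dihydroxyphenyl in the series

The compounds below may be only part of what the source reports. "The series", "measured", "known", "first", "only" and "open" are said of these compounds alone.

In an ADME assay on BJ cells (Homo sapiens) for cytotoxicity, read by MTT assay, with a stated time of 72 h (a higher number here means a weaker inhibitor, a lower number a stronger inhibitor), compound 1 (`Oc1ccc(CNc2ncnc3c2ncn3C2CCCCO2)cc1`) gives > 100000 nM, which is a limit of the assay and not a number. Compound 2 (`COc1cc(CNc2ncnc3c2ncn3C2CCCCO2)ccc1O`) gives > 100000 nM, also a limit. Compound 3 (`COc1ccc(OC)c(CNc2ncnc3c2ncn3C2CCCCO2)c1`) gives > 100000 nM, again a limit. Compound 1 therefore has no readable position in the series, and the whole measured record amounts to the limit of > 100000 nM in this assay, at which 3 of the 3 values shown sit.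

Compound 4 (`Oc1cccc(CNc2ncnc3c2ncn3C2CCCCO2)c1O`) has not yet been measured in this assay. Its change from compound 1 is this: 2,3-dihydroxyphenyl in place of 4-hydroxyphenyl on a saturated chain carbon bound to a nitrogen on an aromatic ring. The hydroxyl count on the aromatic ring goes up, and the 4-hydroxyphenyl group is lost.

Going by the values given here, the one measured step that bears on this is a step that the two limits leave unreadable from compound 1 to compound 2, which puts methoxy in place of hydrogen on an aromatic carbon. That step gives no size to carry over, yet it shows no departure from the limit when the ring gains a substituent. On that basis, the expected result is a number no higher from compound 1 to compound 4 (the limit leaves the size open), with no shift beyond the scatter and with a further limit as the likeliest report. For compound 4 the estimated value is 100000 nM, with an expected range of 50000 nM to 150000 nM.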

Compound 4, half-maximal inhibitory concentration: 63300 nM
Compound 4: middle estimate off by 1.6-fold (0.20 log units), on the high side, within the range that was stated.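

In this assay, going by these compounds alone, compound 4 gives 63300 nM, the only number so far, so a change at this place on the saturated chain carbon bound to a nitrogen on an aromatic ring can yield a readable value. On these data alone, putting 2,3-dihydroxyphenyl in place of 4-hydroxyphenyl gives an at least 1.5-fold lower number from compound 1 to compound 4 (0.19 log units; that floor lies within the scatter), and this printed figure is only a floor, so the true size of the change remains unknown and may or may not exceed the scatter. The steps among the compounds held at the limit cannot be read, and compound 4 is the single departure from an otherwise uniform record: the limit of > 100000 nM in this assay, at which 3 of the 4 values shown sit.

The compounds shown do not separate the effect of the hydroxyl retained in the 2,3-dihydroxyphenyl group from that of the second hydroxyl or from the loss of the 4-hydroxyphenyl group, as all of these arrive in one change. As far as these compounds go, how an aminophenyl or carboxyphenyl group, or a longer chain between the aromatic ring and the nitrogen, would read in this assay also remains open.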